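The source may hold more compounds than are shown below. What is called first, only, known or untested is meant among the compounds shown, and "the series" means these compounds.

- Compound 1 `CSc1ncnc2c1c(-c1ccoc1)cn2[C@@H]1O[C@H](CO)[C@@H](O)[C@H]1O`: 14200 nM
- Compound 2 `C#Cc1cn([C@@H]2O[C@H](CO)[C@@H](O)[C@H]2O)c2ncnc(SC)c12`: > 20000 nM (a limit, not a number)

Going by the values given here, in a functional assay on CCRF-CEM cells (Homo sapiens), read by MTT assay, with a stated time of 72 h (a lower number here means a stronger inhibitor, a higher number a weaker inhibitor), compound 1 gives 14200 nM, the only exact number so far. The other reading is the limit of > 20000 nM in this assay, at which 1 of the 2 values shown sits.

Compound 3 `Cc1ncnc2c1c(-c1ccoc1)cn2[C@@H]1O[C@H](CO)[C@@H](O)[C@H]1O` keeps the furan-3-yl group of compound 1 but has methyl in place of methylsulfanyl on an aromatic carbon. Among the compounds with values here, the only measured step, an at least 1.4-fold higher number from compound 1 to compound 2 (0.14 log units; that floor lies within the scatter), changes a different group, so it says little here, and no measured step touches this place. The expectation is therefore loose: a modest move toward stronger inhibition in this assay, possibly none. The expected change is a 2.4-fold lower number from compound 1 to compound 3 (0.37 log units; beyond the scatter). Compound 3 is estimated at 6000 nM, with an expected range of 800 nM to 20000 nM.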

Compound 3, half-maximal inhibitory concentration: > 20000 nM
Compound 3 gave a limit, no number; the forecaster's own chance of this, stated with the estimate: 20%; at least 3.3-fold (0.52 log units) between middle value and limit.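

Putting methyl in place of methylsulfanyl on this aromatic carbon brings no gain in this assay, with an at least 1.4-fold higher number from compound 1 to compound 3 (0.14 log units; that floor lies within the scatter) as the step. Compound 3 gives only a limit, so this floor cannot separate a real loss from no change. With furan-3-yl kept, only methylsulfanyl at this position gives an exact number, and the comparison stops there because the readings pile up at the top of the range: the limit of > 20000 nM in this assay, at which 2 of the 3 values shown sit.

From the compounds shown here alone, whether an amine or a methoxy group here would bring a measurable number remains open.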